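The compounds below may be only part of what the source reports. "The series", "measured", "known", "first", "only" and "open" are said of these compounds alone.

Measured so far:
- compound 1 `CNc1nc(N)nc2c1ncn2/C=C1/CC1(CO)CO` gives 265000 nM
- compound 2 `CC(C)CSc1nc(N)nc2c1ncn2/C=C1/CC1(CO)CO` gives > 300000 nM as a limit
- compound 3 `CCCCCCCCOc1nc(N)nc2c1ncn2/C=C1/CC1(CO)CO` gives > 300000 nM as a limit

In an ADME assay on HFF cells (Homo sapiens) for cytotoxicity, with a stated time of 8 days (a higher number here means that more compound is tolerated, a lower number that less compound is tolerated), compound 3 gives > 300000 nM as a limit and not a number. This is the limit of > 300000 nM in this assay, at which 2 of the 3 values shown sit, so compound 3 has no exact place in the series.

Compound 4 `CN(C)c1nc(N)nc2c1ncn2/C=C1/CC1(CO)CO` is still unmeasured. It carries dimethylamino in place of octyloxy on an aromatic carbon.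

The closest guide is an at least 1.1-fold higher number from compound 1 to compound 3 (0.05 log units; that floor lies within the scatter), read in reverse, as methylamino is the group that octyloxy replaces there. The step of an at least 1.1-fold higher number from compound 1 to compound 2 (0.05 log units; that floor lies within the scatter) points the same way, while a step that the two limits leave unreadable from compound 2 to compound 3 gives no size. Neither readable floor goes beyond the scatter, so only a small downward change, or none beyond the scatter, is expected in this assay. The expected step is an at least 1.1-fold lower number from compound 3 to compound 4 (0.06 log units; that floor lies within the scatter) and it stays tentative. Compound 1 at 265000 nM anchors the expectation.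

For compound 4 the estimated value is 260000 nM, with an expected range from 130000 nM to 300000 nM.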

Compound 4, half-maximal cytotoxic concentration: > 300000 nM
Compound 4 was reported as a limit; the forecaster's own chance of this, stated with the estimate: 45%; middle value at least 1.1-fold (0.06 log units) from the limit.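

In this assay compound 4 gives > 300000 nM as a limit and not a number. Adding a methyl to the nitrogen gives an at least 1.1-fold higher number from compound 1 to compound 4 (0.05 log units; that floor lies within the scatter) and this is only a floor, so the result does not separate dimethylamino from methylamino on this aromatic carbon; the steps from compound 2 and from compound 3 to compound 4 cannot be read. Dimethylamino now shares one ceiling with isobutylsulfanyl and octyloxy, so no order among these three groups can be given at this position: the limit of > 300000 nM in this assay, at which 3 of the 4 values shown sit.

As far as these compounds go, how far compound 2, compound 3 and compound 4 actually lie from that limit stays open. From the compounds shown here alone, whether any group on this carbon lowers the tolerated concentration beyond the scatter also stays open, for example a carboxylic acid or a longer amine such as octylamino.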